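Phenyl to methyl on a saturated chain carbon: estimate

The source may report more compounds than this note shows. Statements on the series, on what has been measured and on what is new or still open speak of the compounds shown alone.

Measured compounds:
Compound 1, `COc1cccc(C(O)CCn2nc3c(Br)c(Br)c(Br)c(Br)c3n2)c1`: in a functional assay on MCF7 cells (Homo sapiens) for antiproliferative activity, read by MTT assay, with a stated time of 48 h, tested at 100 uM (on this read-out lower numbers stand for a stronger effect and higher numbers for a weaker effect at the one concentration tested), compound 1 gives 6%.
Compound 2, `OC(CCn1nc2c(Br)c(Br)c(Br)c(Br)c2n1)c1cccc(Cl)c1`: in this assay compound 2 gives 0.5%.
Compound 3, `OC(CCn1nc2c(Br)c(Br)c(Br)c(Br)c2n1)c1ccccc1`: in this assay compound 3 gives 0%.

Compound 3 stands lowest of the three numbers. Its nearest neighbour is compound 2, with a number 0.5 percentage points lower from compound 2 to compound 3 (within the scatter); its furthest is compound 1, with a number 6 percentage points lower from compound 1 to compound 3 (within the scatter). The third measured step, a number 5.5 percentage points lower from compound 1 to compound 2 (within the scatter), is likewise within the scatter. All three compounds therefore read as one group with no separation beyond the scatter.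

Compound 4, `CC(O)CCn1nc2c(Br)c(Br)c(Br)c(Br)c2n1`, is not yet measured. Compared with compound 3 the change is methyl in place of phenyl on a saturated chain carbon bound to an oxygen on a saturated carbon and a saturated chain carbon. For the measured compounds named here, none of the measured steps touches this place: each of them exchanges a group on an aromatic carbon of the phenyl that here leaves altogether. The measured steps thus give no direct guide, only the observation that every change so far has stayed within the scatter, and that compound 3 already sits at the floor of the read-out.

For compound 4 in this assay the expected step is a number 3 percentage points higher from compound 3 to compound 4 (within the scatter), that is, none beyond the scatter. The estimated value for compound 4 is 3%, within 0% to 12%.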

Compound 4, a percentage reported as activity, at one concentration (the size of the read-out at that concentration, not a potency): 0%
Compound 4: the middle estimate sits 3 percentage points above what was measured; low and high end bracket the measured number.
By their numbers in this assay, from the lowest: compounds 3, 4, 2 and 1 (each within the scatter of the next).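

For the compounds shown here, the aromatic ring itself goes at this saturated chain carbon, whereas the earlier steps only exchanged groups on that ring, yet in this assay the number holds: no change at the digits printed from compound 3 to compound 4 (within the scatter) and a number 0.5 percentage points lower from compound 2 to compound 4 (within the scatter) and a number 6 percentage points lower from compound 1 to compound 4 (within the scatter). At the one concentration tested, this read-out therefore does not separate methyl from phenyl, 3-chlorophenyl or 3-methoxyphenyl at this place, so none of these aromatic rings is needed to reach the level seen in this set, with compound 4 at 0%. No supporting measurement is available to explain this insensitivity to the change.

With all four compounds grouped at the low end of the read-out, a single concentration cannot show whether they would differ in potency at lower concentrations, or how much of the effect belongs to the shared core alone. From the compounds shown here alone, it also remains open whether a longer chain, an amine or a carboxylic acid in place of the methyl on this carbon would move the number away from this level.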